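This account rests on a few compounds, and the source may have more. Where it says the series, first, only, none or still open, it means among the compounds named here.

Measured so far:
Compound 1, `Cc1ccc(NC(=O)N[C@H](C)c2ccccc2)cc1`, gives 100%.
Compound 2, `CCCCc1ccc(NC(=O)N[C@H](C)c2ccccc2)cc1`, gives 100%.
Compound 3, `C[C@@H](NC(=O)Nc1ccc(C(F)(F)F)cc1)c1ccccc1`, gives 93%.

In an ADME assay on the whole organism with Oryza sativa as the target, tested at 0.1 uM (a lower number here means a stronger effect, a higher number a weaker effect of the compound at the concentration tested), compound 3 carries the lowest of the three numbers, yet its gap to compound 1, a number 7 percentage points lower from compound 1 to compound 3 (within the scatter), and its gap to compound 2, a number 7 percentage points lower from compound 2 to compound 3 (within the scatter), both sit inside the scatter, so the three compounds cannot be ordered. Compound 1 and compound 2 differ from each other by no change at the digits printed from compound 1 to compound 2 (within the scatter).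

Compound 4, `C[C@@H](NC(=O)Nc1ccc(Br)cc1)c1ccccc1`, has not yet been tested. It differs from compound 3 by bromo in place of trifluoromethyl on an aromatic carbon. The two steps that bear on this place, a number 7 percentage points lower from compound 1 to compound 3 (within the scatter) and a number 7 percentage points lower from compound 2 to compound 3 (within the scatter), were each within the scatter, so no step beyond the scatter is expected for compound 4 in this assay, and its estimated step is a number 3 percentage points higher from compound 3 to compound 4 (within the scatter). Compound 4 is expected to give 96%, in the range 86% to 100%.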

Compound 4, a percentage reported as activity, at one concentration (the size of the read-out at that concentration, not a potency): 100%
Estimate against measurement, compound 4: 4 percentage points below; the range from low to high includes it.
By their numbers in this assay, from the lowest: compounds 3, 1, 2 and 4 (each within the scatter of the next).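

In this assay, a single bromine atom on this aromatic carbon, para to a large group, gives a number 7 percentage points higher from compound 3 to compound 4 (within the scatter) and no change at the digits printed from compound 2 to compound 4 (within the scatter) and also no change at the digits printed from compound 1 to compound 4 (within the scatter). Bromo therefore joins methyl, butyl and trifluoromethyl in a set that this assay does not separate at this position, and a halogen atom here produces no step beyond the scatter. No available evidence bears on this result.

Going by these compounds, whether an amine or a carboxylic acid at this place would move the number beyond the scatter remains open. So does the effect of any change elsewhere on the shared core.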